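Swapping the Aryl Group on an Amide Nitrogen

The source may report more compounds than this note shows. Statements on the series, on what has been measured and on what is new or still open speak of the compounds shown alone.

Compound 1 `COc1cc2c(cc1OC)C(CC(=O)O)CC2`: in a functional assay on the whole organism (strain Wistar) for inhibition, with Rattus norvegicus as the target, read by paw edema, with a stated time of 3 h, at a dose of 100 mg/kg (a lower number here means less inhibition, a higher number more inhibition at the dose given (going by the name of the read-out)), compound 1 gives 27.5%.
Compound 2 `COc1cc2c(cc1OC)C(CC(=O)Nc1ccccc1C)CC2`: in this assay compound 2 gives 26.1%.

The two numbers differ only by the step of a number 1.4 percentage points lower from compound 1 to compound 2 (within the scatter), which lies within the scatter, so compound 2 sits level with compound 1. Compound 3 `COc1cc2c(cc1OC)C(CC(=O)Nc1cccnc1)CC2` differs from compound 2 in one place: pyridin-3-yl in place of 2-methylphenyl on an amide-type nitrogen. Among the compounds with values here, no measured step touches this part of the molecule; the only measured step concerns the group on the carbonyl carbon and was small. The step of a number 0.9 percentage points higher from compound 2 to compound 3 (within the scatter) is therefore expected to stay within the scatter. Compound 3 is estimated at 27%, between 14% and 40%.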

Compound 3, a percentage reported as inhibition, in the whole organism at one dose (the size of the read-out at that dose, not a potency): 33.3%
Compound 3: the middle estimate sits 6.3 percentage points below what was measured, within the range that was stated.
By their numbers in this assay, from the lowest: compounds 2, 1 and 3 (each within the scatter of the next).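

Putting pyridin-3-yl in place of 2-methylphenyl on the amide-type nitrogen gives a number 7.2 percentage points higher from compound 2 to compound 3 (within the scatter) in this assay, so this aryl swap, which adds a ring nitrogen and removes a methyl, does not separate the two compounds. The step of a number 5.8 percentage points higher from compound 1 to compound 3 (within the scatter) likewise leaves the pyridinyl amide level with the hydroxy compound. Nothing available explains these numbers.

A plain phenyl group would show what the methyl and the ring nitrogen each contribute. Pyridin-4-yl or a simple alkyl group such as methyl on the same nitrogen remains open too.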